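This account rests on a few compounds, and the source may have more. Where it says the series, first, only, none or still open, it means among the compounds named here.

In a functional assay on MGC-803 cells (Homo sapiens) for inhibition, read by sulforhodamine B assay (a lower number here means a stronger inhibitor, a higher number a weaker inhibitor), compound 1 `O=C1C(Nc2ccccc2)=CC(=O)c2c1nc1n2[C@H]2OC[C@@H](O)[C@H]2OC1` gives 1830 nM, compound 2 `O=C1C=C(Nc2ccccc2F)C(=O)c2c1nc1n2[C@H]2OC[C@@H](O)[C@H]2OC1` gives 2080 nM, and compound 3 `COc1ccc(NC2=CC(=O)c3c(nc4n3[C@H]3OC[C@@H](O)[C@H]3OC4)C2=O)cc1` gives 2150 nM. Compound 2 thus lies within the scatter of both others, and the three cannot be ordered. Compound 4 `COc1ccccc1NC1=CC(=O)c2nc3n(c2C1=O)[C@H]1OC[C@@H](O)[C@H]1OC3` carries methoxy in place of fluoro on an aromatic carbon, ortho to a large group: methoxy in place of fluoro on an aromatic carbon. Going by the values given here, the one measured step that bears on this is a 1.2-fold higher number from compound 1 to compound 3 (0.07 log units; within the scatter), where methoxy replaces hydrogen, though not at the same place. That step stays within the scatter, so no change beyond the scatter is expected in this assay. The expected outcome is an estimated step of a 1.1-fold higher number from compound 2 to compound 4 (0.02 log units; within the scatter). For compound 4 the estimated value is 2200 nM, with an expected range of 1000 nM to 4600 nM.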

Compound 4, half-maximal inhibitory concentration: 1630 nM
For compound 4 the middle estimate is 1.3-fold (0.13 log units) above the measured one; the measured number falls inside the stated range.
By their numbers in this assay, from the lowest: compounds 4, 1, 2 and 3 (each within the scatter of the next).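

Going from 2-fluorophenyl to 2-methoxyphenyl gives a 1.3-fold lower number from compound 2 to compound 4 (0.11 log units; within the scatter) in this assay, so this exchange, on an aromatic carbon ortho to a large group, does not move the number beyond the scatter. The earlier compounds shown here showed methoxy only at another place, replacing hydrogen, whereas here it replaces fluoro. No available evidence bears on this result.

The compounds shown leave open whether any other group at this position would behave the same way. An amine or a carboxylic acid on this carbon could still produce a step beyond the scatter.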